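Can a 4-hydroxyphenyl swap shift cytotoxicity?

The source may hold more compounds than are shown below. What is called first, only, known or untested is meant among the compounds shown, and "the series" means these compounds.

- Compound 1 `COc1ccc(/C=C2\CCC/C(=C\c3ccccc3Br)C2=O)cc1OC`: 9500 nM
- Compound 2 `COc1ccccc1/C=C1\CCC/C(=C\c2ccc(OC)c(OC)c2)C1=O`: 8000 nM

For the measured compounds named here, in a functional assay on MCF7 cells (Homo sapiens) for cytotoxicity, read by MTT assay, with a stated time of 72 h (a lower number here means a stronger inhibitor, a higher number a weaker inhibitor), compound 2 stands level with the only other measured compound, as the data show a 1.2-fold lower number from compound 1 to compound 2 (0.07 log units; within the scatter). Compound 3 `COc1ccc(/C=C2\CCC/C(=C\c3ccc(O)cc3)C2=O)cc1OC` has 4-hydroxyphenyl in place of 2-methoxyphenyl, a change counted as 4-hydroxyphenyl in place of 2-methoxyphenyl on a double-bonded chain carbon bound to a double-bonded ring carbon. Going by the values given here, the one measured step, methoxy in place of bromo on this aromatic ring, stayed small, and no measured compound carries 4-hydroxyphenyl. That gives only weak guidance, so no change beyond the scatter is expected, and the estimate means a 1.1-fold lower number from compound 2 to compound 3 (0.06 log units; within the scatter). Compound 3 is expected at 7000 nM, within an estimated range of 2500 nM to 20000 nM.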

Compound 3, half-maximal inhibitory concentration: 17000 nM
For compound 3 the middle estimate is 2.4-fold (0.39 log units) below the measured one, and the stated range covers the measured number.
By their numbers in this assay, from the lowest: compounds 2, 1 and 3 (each within the scatter of the next, the first and the last beyond it).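

At this place, on a double-bonded chain carbon bound to a double-bonded ring carbon, changing the aromatic group can move the number: in this assay, 4-hydroxyphenyl in place of 2-methoxyphenyl gives a 2.1-fold higher number from compound 2 to compound 3 (0.33 log units; beyond the scatter) and this modest step lies just beyond the scatter. For the compounds shown here, the same group in place of 2-bromophenyl gives a 1.8-fold higher number from compound 1 to compound 3 (0.25 log units; within the scatter) and stays within the scatter, so the shift is clear against only one earlier compound.

From the compounds shown here alone, it remains open whether an amine or a carboxylic acid on this phenyl ring would move the number in the same direction. No measurement shown here gives a reason for the shift.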